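Compound 4: a morpholine swap at the amide end

The source may hold more compounds than are shown below. What is called first, only, known or untested is meant among the compounds shown, and "the series" means these compounds.

Values in a functional assay on A549 cells (Homo sapiens) for inhibition, read by MTT assay, with a stated time of 48 h (on this read-out lower numbers stand for stronger inhibition and higher numbers for weaker inhibition), for the compounds measured so far:
- Compound 1 `Cn1c(/C=C2\SC(=O)N(CC(=O)Nc3cc(C(C)(C)C)on3)C2=O)nc2ccccc21` gives 15300 nM in this test
- Compound 2 `CCn1c(/C=C2\SC(=O)N(CC(=O)Nc3cc(C(C)(C)C)on3)C2=O)nc2ccccc21` gives 44800 nM in this test
- Compound 3 `CCn1c(/C=C2\SC(=O)N(CC(=O)Nc3nc(-c4ccccc4)cs3)C2=O)nc2ccccc21` gives > 50000 nM as a limit of the assay, not a number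

Going by the values given here, of the two true numbers, the one for compound 2 is the higher, and the step that links them is modest (a 2.9-fold higher number from compound 1 to compound 2 (0.47 log units; beyond the scatter)). That step concerns a methyl on a saturated chain carbon bound to an aromatic nitrogen, which is not the part of the molecule that changes next.

Compound 4 `CCn1c(/C=C2\SC(=O)N(CC(=O)N3CCOCC3)C2=O)nc2ccccc21` keeps the rest of compound 2 but carries morpholin-4-yl in place of (5-(tert-butyl)-1,2-oxazol-3-yl)amino on a carbonyl carbon. The measured step that bears most on this change also replaces the 5-(tert-butyl)-1,2-oxazol-3-yl group (an at least 1.1-fold higher number from compound 2 to compound 3 (0.04 log units; that floor lies within the scatter)). From the compounds shown here alone, it gives only a floor, so its true size is unknown, but it offers no sign of a lower number. A small move towards a higher number is therefore expected, and the test may report only a limit.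

The estimated step is small (a 1.3-fold higher number from compound 2 to compound 4 (0.13 log units; within the scatter)). Compound 4 is estimated at 60000 nM in this assay (expected range 25000 nM to 150000 nM).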

Compound 4, half-maximal inhibitory concentration: > 50000 nM
Compound 4: a limit, no number (the forecaster's own chance of this, stated with the estimate: 60%); the middle value does not contradict the limit.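

In this assay compound 4 gives > 50000 nM as a limit of the assay, not a number. Swapping the (5-(tert-butyl)-1,2-oxazol-3-yl)amino group on the carbonyl carbon for morpholin-4-yl removes the hydrogen-bond donor and the five-membered aromatic ring, and the step can be read only as a floor (an at least 1.1-fold higher number from compound 2 to compound 4 (0.04 log units; that floor lies within the scatter)), so its true size stays unknown. Neither replacement at this end has given a lower number than compound 2, but how far the true values of compound 3 and compound 4 lie beyond the limit cannot be read, and the same limit now holds both: the limit of > 50000 nM in this assay, at which 2 of the 4 values shown sit.

The compounds shown leave open how a piperazine, a dimethylamino group or a plain primary amide would behave on this carbonyl carbon, and whether any of them would give a true number. They also leave open whether the methyl of compound 1, which carries the (5-(tert-butyl)-1,2-oxazol-3-yl)amino group, would change the result if paired with morpholin-4-yl at this end.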